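A few compounds are considered here, and "the series" means these few. Any claim that something is new, unique, unknown or untested is made for them only; others in the source may bear on it.

Of the compounds shown here, three sharing one core have been tested in a functional assay on A549 cells (Homo sapiens) for cytotoxicity, read by sulforhodamine B assay; a higher number here means a weaker inhibitor, a lower number a stronger inhibitor. Compound 1 `C=C1[C@@H](OC(C)=O)C[C@@H]2[C@](C)(CO[Si](C)(C)C(C)(C)C)[C@H](OC(C)=O)CC[C@@]2(C)[C@@H]1C[C@@H](Nc1ccc(OC)c(OC)c1)C1=CCOC1=O` gives 4870 nM, compound 2 `C=C1[C@@H](OC(C)=O)C[C@@H]2[C@](C)(COC=O)[C@H](OC(C)=O)CC[C@@]2(C)[C@@H]1C[C@@H](Nc1ccccc1C(=O)O)C1=CCOC1=O` gives 45900 nM, and compound 3 `C=C1[C@@H](OC(C)=O)C[C@@H]2[C@](C)(CO[Si](C)(C)C(C)(C)C)[C@H](OC(C)=O)CC[C@@]2(C)[C@@H]1C[C@@H](Nc1ccccc1C(=O)O)C1=CCOC1=O` gives 4890 nM. Compound 3 thus stands level with compound 1, while compound 2 sits well apart from it.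

The next compound, compound 4 `C=C1[C@@H](OC(C)=O)C[C@@H]2[C@](C)(CO[Si](C)(C)C(C)(C)C)[C@H](OC(C)=O)CC[C@@]2(C)[C@@H]1C[C@@H](Nc1cccc(OC)c1)C1=CCOC1=O`, keeps the core of compound 3 and changes one group: 3-methoxyphenyl in place of 2-carboxyphenyl on an amine nitrogen. In words, 3-methoxyphenyl comes in place of 2-carboxyphenyl on an amine nitrogen.

Two measured steps can be weighed here. Compound 1 carries 3,4-dimethoxyphenyl on that same nitrogen, a close relative of the entering group. Swapping that group for 2-carboxyphenyl gave a 1.0-fold higher number from compound 1 to compound 3 (0.00 log units; within the scatter). This is the best guide, and it shows no change that stands out from the scatter. The other step, a 9.4-fold lower number from compound 2 to compound 3 (0.97 log units; beyond the scatter), is much larger, but it concerns a group on an oxygen on a saturated carbon, and compound 4 leaves that part as it is in compound 3. It therefore says little about this change.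

No step beyond the scatter is expected in this assay, and the estimated step is a 1.1-fold lower number from compound 3 to compound 4 (0.04 log units; within the scatter). With so few compounds, the range stays wide. For compound 4 the estimated value is 4500 nM, with an expected range from 2200 nM to 9500 nM.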

Compound 4, half-maximal inhibitory concentration: 17200 nM
Compound 4: the middle estimate sits 3.8-fold (0.58 log units) below what was measured; the measured number lies above the stated range.
By their numbers in this assay, from the lowest: compounds 1 and 3 (each within the scatter of the next); then compound 4; then compound 2.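

In this assay, the aryl group on the amine nitrogen turns out to matter: 3-methoxyphenyl in place of 2-carboxyphenyl gives a 3.5-fold higher number from compound 3 to compound 4 (0.55 log units; beyond the scatter), a weakening of which the level pair of compound 1 and compound 3 gave no sign. Hydrogen in place of methoxy on an aromatic carbon gives a 3.5-fold higher number from compound 1 to compound 4 (0.55 log units; beyond the scatter), so 3,4-dimethoxyphenyl and 3-methoxyphenyl, close relatives by name, do not behave alike here. Meanwhile 3,4-dimethoxyphenyl and 2-carboxyphenyl, which look far less alike, stand level, so likeness of groups on paper is a poor guide at this nitrogen, at least among these compounds.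

Nothing in the data accounts for what separates these groups. As far as these compounds go, it also remains open whether a plain phenyl, or a phenyl carrying an amine or a hydroxyl, on that nitrogen would stand with compound 4 or with compound 1 and compound 3, and whether the same step would appear with the group that compound 2 carries on its oxygen.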